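The compounds below may be only part of what the source reports. "The series", "measured", "known", "first", "only" and "open" are said of these compounds alone.

Working notes on the series.

Going by the values given here, compound 1, `Cc1ccc(-c2cc(N3CCC(CNS(N)(=O)=O)CC3)ncn2)cc1`, is the only member with a number in a functional assay on M21 cells (Homo sapiens) for antiproliferative activity, read by sulforhodamine B assay, with a stated time of 48 h; a lower number here means a stronger inhibitor of growth, a higher number a weaker inhibitor of growth: compound 1 gives 71000 nM. Compound 2, `NS(=O)(=O)NCC1CCN(c2cc(-c3ccccc3Cl)ncn2)CC1`, carries 2-chlorophenyl in place of 4-methylphenyl on an aromatic carbon. In this assay compound 2 reaches only a limit, > 100000 nM. The step of an at least 1.4-fold higher number from compound 1 to compound 2 (0.14 log units; that floor lies within the scatter) is thus bounded from below only, and the one fact behind it is the limit of > 100000 nM in this assay, at which 1 of the 2 values shown sits.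

Compound 3, `Cc1ccc(-c2cc(N3CCC(CCNS(N)(=O)=O)CC3)ncn2)cc1`, is not yet measured. It differs from compound 1 as follows: (sulfamoylamino)methyl in place of sulfamoylamino on a saturated chain carbon bound to a saturated ring carbon. Among the compounds with values here, no measured step touches this chain; the single step known, from compound 1 to compound 2, changes the aryl group and ends at a limit, so it gives no guide to a one-carbon extension on the saturated chain. Without any comparable step, no shift beyond the scatter is expected from compound 1 to compound 3, and the estimated step is no change at the digits printed from compound 1 to compound 3 (within the scatter). Compound 3 is therefore expected near 71000 nM, within 25000 nM to 200000 nM, with a fair chance that this assay again returns only a limit.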

Compound 3, concentration for 50% growth inhibition: 57600 nM
For compound 3 the middle estimate is 1.2-fold (0.09 log units) above the measured one; the measured number falls inside the stated range.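

In this assay, exchanging (sulfamoylamino)methyl for 2-(sulfamoylamino)ethyl on a saturated chain carbon bound to a saturated ring carbon gives a 1.2-fold lower number from compound 1 to compound 3 (0.09 log units; within the scatter). Going by these compounds alone, this is the first reading at the saturated chain, and it has a number at both ends, so the size of the step can be read directly and the chain length tried here leaves the activity within the scatter. Compound 2 remains the only member at a limit, which is not a number, so the aryl step still has a floor and no size: the limit of > 100000 nM in this assay, at which 1 of the 3 values shown sits.

The compounds shown leave open whether a longer chain, such as 3-(sulfamoylamino)propyl, would also stay within the scatter of compound 1, and whether the sulfamoylamino end itself matters, which a carboxylic acid or a primary amine at the same place would test. They also leave open whether any aryl group other than 4-methylphenyl on the shared core gives a number rather than a limit, for example 4-methoxyphenyl or unsubstituted phenyl.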